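The source may hold more compounds than are shown below. What is called first, only, known or untested is meant among the compounds shown, and "the series" means these compounds.

Among the measured compounds shown here, in an assay on isolated protein for inhibition of aldehyde dehydrogenase 1A1 (Homo sapiens), read by spectrophotometry, tested at 10 uM (a higher number here means more inhibition at the concentration tested (going by the name of the read-out), a lower number less inhibition), compound 3 `Cc1cccc(Cn2c(CN3CCN(C(=O)C4CCCCC4)CC3)nc3ccccc32)c1` gives 31.9%, the second highest of the three numbers measured so far. Compound 1 `Cc1cccc(Cn2c(CN3CCN(C(=O)c4ccc(C(F)(F)F)cc4)CC3)nc3ccccc32)c1` gives 22.9%, so that the step of a number 9 percentage points higher from compound 1 to compound 3 (within the scatter) is within the scatter. Compound 2 `Cc1cccc(Cn2c(CN3CCN(C(=O)CC(C)C)CC3)nc3ccccc32)c1` gives 71.4%, and the step of a number 39.5 percentage points lower from compound 2 to compound 3 (beyond the scatter) is large. Compound 4 `Cc1ccc(C(=O)N2CCN(Cc3nc4ccccc4n3Cc3cccc(C)c3)CC2)cc1` has not been measured; it carries 4-methylphenyl in place of cyclohexyl on a carbonyl carbon. For the measured compounds named here, the one step that bears on this change is the earlier exchange of 4-(trifluoromethyl)phenyl for cyclohexyl on the same carbonyl carbon, a number 9 percentage points higher from compound 1 to compound 3 (within the scatter), which stayed within the scatter, so little movement beyond the scatter is expected here. The expected step is therefore a number 5.9 percentage points lower from compound 3 to compound 4 (within the scatter). Compound 4 is estimated to give about 26%, between 10% and 45%.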

Compound 4, a percentage reported as inhibition, at one concentration (the size of the read-out at that concentration, not a potency): 64.9%
Beside the measured number, compound 4's estimate is 38.9 percentage points below it; the measured number lies above the stated range.
By their numbers in this assay, from the lowest: compounds 1 and 3 (each within the scatter of the next); then compounds 4 and 2 (each within the scatter of the next).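

At this carbonyl carbon, an aromatic ring alone does not fix the result in this assay: methyl in place of trifluoromethyl on an aromatic carbon gives a number 42 percentage points higher from compound 1 to compound 4 (beyond the scatter). Cyclohexyl and 4-methylphenyl, both six-membered rings, also part widely, with a number 33 percentage points higher from compound 3 to compound 4 (beyond the scatter), whereas 4-methylphenyl in place of isobutyl gives a number 6.5 percentage points lower from compound 2 to compound 4 (within the scatter). Nothing available here accounts for these steps. Still open, from the compounds shown here alone, is whether chlorine or methoxy on that aromatic carbon would behave like methyl or like trifluoromethyl, and whether a longer chain would match isobutyl.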